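Ether, thioether and amine variants on the diamino core

This account rests on a few compounds, and the source may have more. Where it says the series, first, only, none or still open, it means among the compounds named here.

Compound 3 `Nc1cc(N)c2nc(-c3ccccc3)c(Sc3ccc(Cl)c(Cl)c3)nc2c1` carries a (3,4-dichlorophenyl)sulfanyl group on the shared core. In a functional assay on SR cells (Homo sapiens) for inhibition, read by sulforhodamine B assay, with a stated time of 48 h (on this read-out higher numbers stand for lower toxicity in this test and lower numbers for higher toxicity in this test), compound 3 gives < 100000 nM, which is a limit of the assay and not a number. Compound 1 `Nc1cc(N)c2nc(-c3ccccc3)c(Oc3ccc(Cl)c(Cl)c3)nc2c1` is the oxygen analogue with the same dichlorinated ring; in this assay compound 1 gives < 100000 nM, again a limit. Compound 2 `Nc1cc(N)c2nc(-c3ccccc3)c(NCc3ccc(F)cc3)nc2c1` replaces the aryl ether by a (4-fluorobenzyl)amino group; in this assay compound 2 gives < 100000 nM, also a limit. The steps between these three, a step that the two limits leave unreadable from compound 1 to compound 3, a step that the two limits leave unreadable from compound 2 to compound 3 and a step that the two limits leave unreadable from compound 1 to compound 2, cannot be read, since every value sits at the limit of < 100000 nM in this assay, at which 3 of the 3 values shown sit.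

Compound 4 `Nc1cc(N)c2nc(-c3ccccc3)c(Oc3ccc(F)cc3)nc2c1` differs from compound 3 by 4-fluorophenoxy in place of (3,4-dichlorophenyl)sulfanyl on an aromatic carbon. The nearest measured step, the oxygen-for-sulfur exchange in a step that the two limits leave unreadable from compound 1 to compound 3, gives no size, and the fluorinated ring of compound 2 is attached through a different linker. Among the compounds with values here, no measured step therefore points to a direction, and the expectation is that compound 4 stays in the same region as the three measured compounds, with a step that the limit leaves unreadable from compound 3 to compound 4 expected to be unreadable in the same way. The estimate for compound 4 in this assay is 60000 nM, expected between 8000 nM and 100000 nM, most likely reported once more only as a limit.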

Compound 4, concentration lethal to 50% of the cells: < 100000 nM
Compound 4: a limit, no number (the forecaster's own chance of this, stated with the estimate: 80%); the middle value lies beyond the limit too.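

In this assay compound 4 gives < 100000 nM, a limit of the assay and not a number. No step between compound 4 and compound 1, compound 2 or compound 3 can be read, since all four compounds sit at one limit: the limit of < 100000 nM in this assay, at which 4 of the 4 values shown sit.

The compounds shown leave open whether linker or ring substitution on the shared core changes the result in this assay at all.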